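Adding Bromine to a Series Sitting at the Assay Limit

The compounds below may be only part of what the source reports. "The series", "measured", "known", "first", "only" and "open" are said of these compounds alone.

Compound 1 `COc1ccc(-c2ocnc2-c2cc(OC)c(OC)c(OC)c2)cc1S` gives > 20000 nM in a functional assay on A549 cells (Homo sapiens) for cytotoxicity, read by MTT assay, with a stated time of 48 h (on this read-out higher numbers stand for weaker inhibition and lower numbers for stronger inhibition), a limit of the assay rather than a number.
Compound 2 `COc1cc(/C=C\c2cccc(OC)c2SC)cc(OC)c1OC` gives > 20000 nM in this assay, again only a limit.
Compound 3 `COc1cc(-c2ocnc2-c2cc(OC)c(OC)c(OC)c2)ccc1SC` gives > 20000 nM in this assay, also a limit and not a number.

Compound 3 therefore stands nowhere in particular on a scale of numbers: it shares the limit of > 20000 nM in this assay, at which 3 of the 3 values shown sit, with every other compound shown, and no two compounds here differ in one place, so no measured step exists to show how any single change moves the read-out.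

Compound 4 `COc1cc(-c2ncoc2-c2cc(Br)c(SC)c(OC)c2)cc(OC)c1OC` differs from compound 3 in one place: bromo in place of hydrogen on an aromatic carbon. With nothing measured to lean on, no change beyond the usual scatter is expected for the step that the limit leaves unreadable from compound 3 to compound 4, and compound 4 is expected most likely to come back as a limit as well. As a number, compound 4 is estimated at 25000 nM, with a plausible range from 5000 nM to 100000 nM, the wide range reflecting that the starting point itself is only a limit.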

Compound 4, half-maximal inhibitory concentration: > 20000 nM
Compound 4 ended at the assay's limit (the forecaster's own chance of this, stated with the estimate: 70%); the middle value is on the limit's open side.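

Compound 3 and compound 4 both come back as limits rather than numbers, so the step between them, bromo in place of hydrogen, cannot be read. The compounds shown leave open how any single change moves the read-out, since every one shares a single ceiling: the limit of > 20000 nM in this assay, at which 4 of the 4 values shown sit.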